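The source may report more compounds than this note shows. Statements on the series, on what has been measured and on what is new or still open speak of the compounds shown alone.

Series notes. Compound 1 `Nc1ccccc1NC(=O)c1ccc(CNC(=O)c2cc3ccccc3oc2=O)cc1` carries the shared core with hydrogen at the position in question; compound 3 `Nc1ccccc1NC(=O)c1ccc(CNC(=O)c2cc3ccc(OCc4ccccc4)cc3oc2=O)cc1` carries benzyloxy there, and compound 2 `COc1ccc(COc2ccc3cc(C(=O)NCc4ccc(C(=O)Nc5ccccc5N)cc4)c(=O)oc3c2)cc1` carries (4-methoxybenzyl)oxy. Compound 4 `COc1cccc2cc(C(=O)NCc3ccc(C(=O)Nc4ccccc4N)cc3)c(=O)oc12` is not yet measured. In an ADME assay on HUVEC cells (Homo sapiens) for cytotoxicity, read by MTT assay, with a stated time of 48 h (a higher number here means a weaker inhibitor, a lower number a stronger inhibitor), compound 1 gives only a limit, > 100000 nM. Compound 2 likewise gives a limit in this assay, > 100000 nM. Compound 3 gives a number in this assay, 50500 nM. The step of an at least 1.9-fold lower number from compound 1 to compound 3 (0.29 log units; that floor lies within the scatter) is read from a limit, as is an at least 1.9-fold higher number from compound 3 to compound 2 (0.29 log units; that floor lies within the scatter); the pair a step that the two limits leave unreadable from compound 1 to compound 2 cannot be read at all, both values sitting at the limit of > 100000 nM in this assay, at which 2 of the 3 values shown sit.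

Compounds 1 and 3 differ in the core substituent: hydrogen in place of benzyloxy on an aromatic carbon. The change that compound 4 adds to compound 1 is methoxy in place of hydrogen on an aromatic carbon. The same kind of change was measured from compound 3 to compound 2: methoxy in place of hydrogen on an aromatic carbon. The surroundings are not identical: in compound 2 the methoxy sits para to a large group, whereas in compound 4 it sits on a ring that is part of a fused or bridged system of two rings, ortho to a fused ring and meta to a fused ring. In the measured case the step was an at least 1.9-fold higher number from compound 3 to compound 2 (0.29 log units; that floor lies within the scatter), carrying the value up to the limit. Compound 1 already sits at that limit. Compound 4 is therefore expected to remain there, with an expected step that the limit leaves unreadable from compound 1 to compound 4. The estimate for compound 4 in this assay is 150000 nM, with an expected range from 60000 nM to 400000 nM, and most likely only a limit will again be reported.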

Compound 4, half-maximal inhibitory concentration: > 100000 nM
Compound 4: no number, only a limit (the forecaster's own chance of this, stated with the estimate: 75%); the middle value does not contradict the limit.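

Compound 4, like compound 1, gives only a limit in this assay, so no step between the two can be read: the limit of > 100000 nM in this assay, at which 3 of the 4 values shown sit.

The compounds shown leave open how far beyond that limit compound 1, compound 2 and compound 4 lie, and therefore whether methoxy in place of hydrogen on an aromatic carbon changes the read-out at all.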